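The source may report more compounds than this note shows. Statements on the series, on what has been measured and on what is new or still open speak of the compounds shown alone.

Working notes on the series. Compound 1 `CCN(CC)c1ccc(/C=C/C(=O)c2ccc(OC)c3c2OC(C)(C)C=C3)cc1` and compound 2 `COc1ccc(C(=O)/C=C/c2ccc(N3CCCC3)cc2)c2c1C=CC(C)(C)O2` share a core and differ only at one aromatic carbon. In a functional assay on K562 cells (Homo sapiens) for antiproliferative activity, read by MTT assay, with a stated time of 24 h (a lower number here means a stronger inhibitor, a higher number a weaker inhibitor), compound 1 gives 790 nM, and compound 2 gives 6180 nM; the step of a 7.8-fold higher number from compound 1 to compound 2 (0.89 log units; beyond the scatter) separates them. For the measured compounds named here, on the numbers so far compound 2 stands highest of the two, with compound 1 as its only neighbour.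

Compound 3 `COc1ccc(C(=O)/C=C/c2ccccc2)c2c1C=CC(C)(C)O2` is not yet measured. Its change from compound 2 is hydrogen in place of pyrrolidin-1-yl on an aromatic carbon, placed on an aromatic carbon of a six-membered aromatic ring of carbon only, para to a large group. Going by the values given here, the only measured step touching this position is a 7.8-fold higher number from compound 1 to compound 2 (0.89 log units; beyond the scatter), which shows that exchanging one amine for another at this carbon already moved the number beyond the scatter. Among the compounds with values here, no measured pair removes the amine altogether, so direction is open; a further step beyond the scatter is plausible either way, and the estimate leans toward a higher number for compound 3, a 1.5-fold higher number from compound 2 to compound 3 (0.16 log units; within the scatter). Compound 3 is therefore expected at 9000 nM in this assay, within 2000 nM to 40000 nM.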

Compound 3, half-maximal inhibitory concentration: > 10000 nM
Compound 3 ended at the assay's limit; the forecaster's own chance of this, stated with the estimate: 20%; middle value at least 1.1-fold (0.04 log units) from the limit.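

In this assay compound 3 stands at a limit of the assay and not at a number: the limit of > 10000 nM in this assay, at which 1 of the 3 values shown sits.

Hydrogen in place of pyrrolidin-1-yl gives an at least 1.6-fold higher number from compound 2 to compound 3 (0.20 log units; that floor lies within the scatter), so this pair sets only a floor and does not establish a difference beyond the scatter. Hydrogen in place of diethylamino gives an at least 12-fold higher number from compound 1 to compound 3 (1.10 log units; beyond the scatter), which shows for the first time that removing an amine from this carbon, and not merely exchanging one amine for another, can move the number beyond the scatter, and that it moves it upward.

On these data alone, whether pyrrolidin-1-yl holds any real advantage over hydrogen stays open, as the true value of compound 3 is unknown. Also open, as far as these compounds go, is where a piperidin-1-yl, a dipropylamino or a methoxy group at this carbon would fall.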